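The source may report more compounds than this note shows. Statements on the series, on what has been measured and on what is new or still open speak of the compounds shown alone.

Measured compounds:
compound 1 `COc1cc(C(=O)N/N=C/c2ccc(F)c(F)c2)cc(OC)c1OC` — 35.1%
compound 2 `COc1ccc(/C=N/NC(=O)c2cc(OC)c(OC)c(OC)c2)c(OC)c1` — 10%
compound 3 `COc1cc(C2=NN(C(C)=O)C(c3cc(Cl)cc(Cl)c3)O2)cc(OC)c1OC` — 52.7%

In a functional assay on PC-3 cells (Homo sapiens) for antiproliferative activity, read by MTT assay, tested at 1 uM (a lower number here means a weaker effect, a higher number a stronger effect of the compound at the concentration tested), compound 1 stands second highest of the three numbers. Compound 3 lies higher, beyond the scatter, and compound 2 lies lower, also beyond the scatter. Among the compounds with values here, no pair among the measured compounds differs in only one place, so no single-change step is available for comparison.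

Compound 4 `COc1cc(C(=O)N/N=C/c2cccc(F)c2)cc(OC)c1OC` differs from compound 1 by hydrogen in place of fluoro on an aromatic carbon. Without a measured step of this kind, the expectation rests on compound 1 alone; the step of a number 6.1 percentage points lower from compound 1 to compound 4 (within the scatter) is expected to be small, within the scatter or slightly downward. Compound 4 is estimated at 29%, with a range from 13% to 45%.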

Compound 4, a percentage reported as inhibition, at one concentration (the size of the read-out at that concentration, not a potency): 53.5%
Compound 4: middle estimate off by 24.5 percentage points, on the low side, and the stated range ends below it.
By their numbers in this assay, from the lowest: compound 2; then compound 1; then compounds 3 and 4 (each within the scatter of the next).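

In this assay, within the data shown here, going from 3,4-difluorophenyl to 3-fluorophenyl gives the first single-change step: a number 18.4 percentage points higher from compound 1 to compound 4 (beyond the scatter). At this position, then, the fluoro group is not needed for the effect at the concentration tested, and hydrogen in its place reads stronger. No measurement shown explains this step. Still open, on these data alone, is how an amine, a carboxylic acid or a nitrile would read on this aromatic carbon. Also open, as far as these compounds go, is whether the remaining fluoro group contributes to the effect of compound 4.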